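Replacing an aryl urea end with a butyl chain

The source may report more compounds than this note shows. Statements on the series, on what has been measured and on what is new or still open speak of the compounds shown alone.

Measured so far:
- compound 1 `CC(C)CN(CC(C)C)c1ccc(/C(=N/O)Nc2ccc(F)c(Br)c2)cc1NC(=O)Nc1ccc(Cl)cc1` gives 440 nM
- compound 2 `Cc1ccc(NC(=O)Nc2cc(/C(=N/O)Nc3ccc(C)cc3)ccc2N(CC(C)C)CC(C)C)cc1` gives 1340 nM
- compound 3 `Cc1ccc(N/C(=N\O)c2ccc(N(CC(C)C)CC(C)C)c(NC(=O)Nc3cncnc3)c2)cc1` gives 440 nM

All three numbers come from an assay on HeLa cells for inhibition of Indoleamine 2,3-dioxygenase 1 (Homo sapiens); a higher number here means a weaker inhibitor, a lower number a stronger inhibitor. Compound 1 stands level with compound 3 at the digits shown, and together they carry the lowest numbers of the set; compound 2 sits apart with a higher number, a gap beyond the scatter. For the measured compounds named here, the only step measured so far at the urea end is a 3.0-fold lower number from compound 2 to compound 3 (0.48 log units; beyond the scatter), which shows that what hangs on that amide-type nitrogen can move the read-out by a modest but real amount.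

Compound 4 `CCCCNC(=O)Nc1cc(/C(=N/O)Nc2ccc(F)c(Br)c2)ccc1N(CC(C)C)CC(C)C` is not yet measured. It differs from compound 1 by butyl in place of 4-chlorophenyl on an amide-type nitrogen. Going by the values given here, no measured step exchanges an aromatic ring for an open chain at this place, so the step from compound 2 to compound 3 tells only that this position matters, not which way a butyl group will go. Compound 4 is therefore expected to land near compound 1 with a wide range, leaning toward a somewhat higher number, an expected step of a 2.0-fold higher number from compound 1 to compound 4 (0.31 log units; beyond the scatter), giving an estimate of 900 nM between 250 nM and 3500 nM in this assay.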

Compound 4, half-maximal inhibitory concentration: 3110 nM
Beside the measured number, compound 4's estimate is 3.5-fold (0.54 log units) below it, within the range that was stated.
By their numbers in this assay, from the lowest: compounds 1 and 3 (each within the scatter of the next); then compound 2; then compound 4.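

In this assay, for the compounds shown here, the exchange of 4-chlorophenyl for butyl on the amide-type nitrogen gives a 7.1-fold higher number from compound 1 to compound 4 (0.85 log units; beyond the scatter), the first measured step at this place that trades an aromatic ring for an open chain. The earlier step here, a 3.0-fold lower number from compound 2 to compound 3 (0.48 log units; beyond the scatter), kept an aromatic ring at both ends, so only now is a direction seen for a ring-to-chain change: in this pair, the butyl compound carries the higher number. Nothing available explains this shift.

On these data alone, whether the shift follows from losing the aromatic ring or from the butyl chain itself stays open, and a cyclohexyl ring or a benzyl group on this nitrogen would help to separate the two. As far as these compounds go, the change is also read in this single pair only, so its size with other groups elsewhere on the shared core is unknown.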